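Chlorobenzyl Position Swap on a Shared Core in Rat Artery

The compounds below may be only part of what the source reports. "The series", "measured", "known", "first", "only" and "open" are said of these compounds alone.

Of the compounds shown here, three built on one shared core have been tested in a functional assay on the whole organism (artery, strain albino) with Rattus norvegicus as the target, with a stated time of 360 min, at a dose of 10 mg/kg by the oral route; a lower number here means less inhibition, a higher number more inhibition at the dose given (going by the name of the read-out). Compound 1 `CC1=C(C(=O)Nc2ccc(F)cc2)C(c2ccc([N+](=O)[O-])cc2)N=C(SCc2ccccc2Cl)N1` gives 21.6% in this assay. Compound 2 `CC1=C(C(=O)Nc2ccc(F)cc2)C(c2ccc([N+](=O)[O-])cc2)N=C(SCc2cccc(Cl)c2)N1` differs from compound 1 in one place, by 3-chlorophenyl in place of 2-chlorophenyl on a saturated chain carbon bound to a sulfur, and in this assay compound 2 gives 21.1%. The measured step between them is a number 0.5 percentage points lower from compound 1 to compound 2 (within the scatter). Compound 3 `CC1=C(C(=O)Nc2ccc([N+](=O)[O-])cc2)C(c2ccc(Br)cc2)N=C(SCc2ccccc2Cl)N1` carries a different core; how it differs from the core of compound 1 is not broken down here. In this assay compound 3 gives 13.9%, a number whose gaps to compound 2 and to compound 1 both lie within the usual scatter, so no order among the three can be read from these values.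

Compound 4 `CC1=C(C(=O)Nc2ccc([N+](=O)[O-])cc2)C(c2ccc(Br)cc2)N=C(SCc2cccc(Cl)c2)N1` has not yet been measured in this assay. It differs from compound 3 by 3-chlorophenyl in place of 2-chlorophenyl on a saturated chain carbon bound to a sulfur. This is the same change, at the same place, that was made from compound 1 to compound 2, and that change is seen twice among the compounds shown. Since the measured step was a number 0.5 percentage points lower from compound 1 to compound 2 (within the scatter), the step from compound 3 to compound 4 is expected to be small as well, estimated at a number 0.4 percentage points lower from compound 3 to compound 4 (within the scatter). On that basis, and because compound 3 gives 13.9%, compound 4 is expected to give about 13.5% in this assay, estimated to fall between 5% and 23%.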

Compound 4, a percentage reported as inhibition, in the whole organism at one dose (the size of the read-out at that dose, not a potency): 7.2%
Compound 4: the middle estimate sits 6.3 percentage points above what was measured, and the stated range covers the measured number.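

In this assay, the exchange of 2-chlorobenzyl for 3-chlorobenzyl on the second core gives a number 6.7 percentage points lower from compound 3 to compound 4 (within the scatter), so neither core yields a step that can be told from the usual variation between repeated measurements. Set side by side, the two steps do not differ by more than that variation allows, and as far as these two pairs can show, the change carries from one core to the other without a detectable difference: the same change on two cores in this assay, a number 0.5 percentage points lower (within the scatter) from compound 1 to compound 2 and a number 6.7 percentage points lower (within the scatter) from compound 3 to compound 4, 6.2 percentage points apart, within the scatter of two such steps. This does not show that the change has a real effect on either core, that the two steps are truly equal, or that the same would hold on any further core, and the apparently larger number on the second core cannot be taken as a sign that this core responds more strongly.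

The compounds shown leave open what happens when something other than a chlorophenyl sits on a saturated chain carbon bound to a sulfur, for instance an unsubstituted phenyl, a pyridine ring, a carboxylic acid or an amine. They also leave open whether a longer chain in that place would give a step large enough to be read in this assay.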